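Swapping the Sulfonyl Aryl Group: Compound 2 to Compound 3

The source may report more compounds than this note shows. Statements on the series, on what has been measured and on what is new or still open speak of the compounds shown alone.

Measured so far:
compound 1, `O=S(=O)(Nc1ccc2oc(-c3ccccc3)nc2c1)c1cccs1`, 90000 nM
compound 2, `O=S(=O)(Nc1ccc2oc(-c3ccccc3)nc2c1)c1ccc(Cl)c(Cl)c1`, > 100000 nM

In an assay on cells for inhibition of HSP60/HSP10 (Homo sapiens), with a stated time of 60 min (on this read-out lower numbers stand for stronger inhibition and higher numbers for weaker inhibition), compound 1 gives 90000 nM. For compound 2 the read-out is only a limit of the assay, > 100000 nM, so compound 2 stands at the limit of > 100000 nM in this assay, at which 1 of the 2 values shown sits, rather than at a number. For the measured compounds named here, the single measured step, an at least 1.1-fold higher number from compound 1 to compound 2 (0.04 log units; that floor lies within the scatter), lies within the scatter. Compound 3 `O=S(=O)(Nc1ccc2oc(-c3ccccc3)nc2c1)c1ccc(Cl)s1` differs from compound 2 by 5-chlorothiophen-2-yl in place of 3,4-dichlorophenyl on a sulfonyl sulfur. Going by the values given here, with compound 2 at a limit and the only measured step within the scatter, no step beyond the scatter is expected in this assay; the expected step is a step that the limit leaves unreadable from compound 2 to compound 3. Compound 3 is expected near 120000 nM, within 50000 nM to 300000 nM, and quite possibly again reported only as a limit.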

Compound 3, half-maximal inhibitory concentration: 70000 nM
For compound 3 the middle estimate is 1.7-fold (0.23 log units) above the measured one, within the range that was stated.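

Chloro in place of hydrogen on an aromatic carbon gives a 1.3-fold lower number from compound 1 to compound 3 (0.11 log units; within the scatter), so adding this group to the sulfonyl aryl ring produces no readable change. 5-chlorothiophen-2-yl in place of 3,4-dichlorophenyl on a sulfonyl sulfur gives an at least 1.4-fold lower number from compound 2 to compound 3 (0.15 log units; that floor lies within the scatter), and this floor shows no step beyond the scatter either. Compound 2 remains a limit of the assay rather than a number: the limit of > 100000 nM in this assay, at which 1 of the 3 values shown sits.

Still open, as far as these compounds go, is whether any group on this sulfonyl sulfur can give a step beyond the scatter. An aromatic ring carrying an amine or a carboxylic acid would test this, as would changes elsewhere on the shared core.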